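Swapping the group on the sulfonyl sulfur of compound 2

A few compounds are considered here, and "the series" means these few. Any claim that something is new, unique, unknown or untested is made for them only; others in the source may bear on it.

In an ADME assay on microsomes (Mus musculus) for metabolic stability (on this read-out lower numbers stand for slow clearance and higher numbers for fast clearance), compound 2 `COC[C@@H]1CCCN1S(=O)(=O)c1ccc(Cl)c(COc2cccc3c(C(F)(F)F)cc(C)nc23)c1Cl` gives 1620 mL/min/kg. The only other measured structure, compound 1 `CCc1cc(C(F)(F)F)c2cccc(OCc3c(Cl)ccc(S(=O)(=O)N4CCC[C@H]4C(=O)NC)c3Cl)c2n1`, gives 1280 mL/min/kg, and these two values lie within the scatter of each other. Clearance is therefore fast for both. The unmeasured compound 3 `Cc1cc(C(F)(F)F)c2cccc(OCc3c(Cl)ccc(S(=O)(=O)N4C[C@@H](C)O[C@@H](C)C4)c3Cl)c2n1` has the same atoms as compound 2, joined differently, with 2,6-dimethylmorpholin-4-yl in place of 2-(methoxymethyl)pyrrolidin-1-yl on a sulfonyl sulfur. Going by the values given here, no measured step isolates a change of this kind, so the expectation rests only on the closeness of the two values in this assay. No move beyond the scatter is expected, and the estimated step of a 1.2-fold lower number from compound 2 to compound 3 (0.06 log units; within the scatter) has no firm direction. For compound 3 the expected clearance is 1400 mL/min/kg, with an estimated range of 700 mL/min/kg to 2600 mL/min/kg.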

Compound 3, clearance: 933 mL/min/kg
The estimate for compound 3 lay 1.5-fold (0.18 log units) above the measured number, within the range that was stated.
By their numbers in this assay, from the lowest: compounds 3, 1 and 2 (each within the scatter of the next).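

On a sulfonyl sulfur whose other neighbour is an aromatic carbon, 2,6-dimethylmorpholin-4-yl in place of 2-(methoxymethyl)pyrrolidin-1-yl gives, in this assay, a 1.7-fold lower number from compound 2 to compound 3 (0.24 log units; within the scatter). This single step shows that exchanging a five-membered ring with 1 hetero atom for a six-membered ring with 2 hetero atoms, at an equal count of heavy atoms, does not carry the read-out beyond the scatter. Nothing measured alongside these numbers helps to interpret the step.

Going by these compounds, it remains open whether plain morpholin-4-yl, without the two methyl groups, would read differently from the 2,6-dimethyl ring. Also open, on these data alone, is whether a carboxylic acid on the pyrrolidine ring or an open-chain diethylamino group on the sulfur would move clearance beyond the scatter.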